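Swapping hydroxy for hydrogen on compound 3

This account rests on a few compounds, and the source may have more. Where it says the series, first, only, none or still open, it means among the compounds named here.

In a functional assay on CCRF-CEM cells (Homo sapiens) for antiproliferative activity, with a stated time of 72 h (on this read-out higher numbers stand for an effect only at larger amounts of compound and lower numbers for an effect already at smaller amounts), compound 3 (`Cc1cn([C@@H]2O[C@H](CO)[C@@H](CN)[C@@H]2O)c(=O)[nH]c1=O`) gives > 100 uM as a limit of the assay. Compound 2 (`Cc1cn([C@@H]2O[C@H](CO)[C@@H](CN)[C@H]2O)c(=O)[nH]c1=O`) gives > 100 uM as a limit too. Compound 1 (`Cc1cn([C@H]2C[C@H](CF)[C@@H](CO)O2)c(=O)[nH]c1=O`) gives > 100 uM as a limit as well. Compound 3 thus stands at the limit of > 100 uM in this assay, at which 3 of the 3 values shown sit, and has no exact value. Compound 4 (`Cc1cn([C@H]2C[C@H](CN)[C@@H](CO)O2)c(=O)[nH]c1=O`) carries hydrogen in place of hydroxy on a saturated ring carbon compared with compound 3. Among the compounds with values here, the only measured step is a step that the two limits leave unreadable from compound 2 to compound 3 and it offers no size to carry over, reflecting only the fact that compounds 2 and 3 differ only in the configuration as drawn here. The expected change is a step that the limit leaves unreadable from compound 3 to compound 4 with no direction beyond the scatter foreseen. For compound 4 the estimated value is 150 uM within an expected range of 60 uM to 400 uM and most likely reported as a limit again.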

Compound 4, concentration for half-maximal effect: > 100 uM
Compound 4 was reported as a limit; the forecaster's own chance of this, stated with the estimate: 85%; the middle value lies beyond the limit too.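

Compound 4 gives > 100 uM, again a limit of the assay, so its steps from compound 1, compound 2 and compound 3 cannot be read. The compounds shown leave open whether hydroxy or hydrogen on the saturated ring carbon makes any difference in this assay.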